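Working notes: bromo to methoxy on the shared core

A few compounds are considered here, and "the series" means these few. Any claim that something is new, unique, unknown or untested is made for them only; others in the source may bear on it.

- compound 1 `Clc1ccc(-c2nn(-c3ccccc3)cc2-c2nc3ccccc3[nH]2)cc1`: 5960 nM
- compound 2 `Clc1ccc(-c2nn(-c3ccccc3)cc2-c2nc3cc(Br)ccc3[nH]2)cc1`: 2170 nM
- compound 3 `COc1ccc2[nH]c(-c3cn(-c4ccccc4)nc3-c3ccc(Cl)cc3)nc2c1`: not yet measured

Among the measured compounds shown here, in a functional assay on A549 cells (Homo sapiens) for antiproliferative activity, read by MTT assay, with a stated time of 48 h (on this read-out lower numbers stand for stronger inhibition and higher numbers for weaker inhibition), compound 2 gives 2170 nM, the lower of the two numbers so far, and its nearest neighbour, compound 1, gives 5960 nM. Compound 3 carries methoxy in place of bromo on an aromatic carbon, on a six-membered aromatic ring of carbon only that is part of a fused system of two rings: methoxy in place of bromo on an aromatic carbon. For the measured compounds named here, one measured step bears on this change, a 2.7-fold lower number from compound 1 to compound 2 (0.44 log units; beyond the scatter), which is modest and comes from bromo in place of hydrogen at that same carbon. Going by the values given here, the series holds no methoxy example, so the direction is uncertain. With the bromo gone, part of that step may be lost, so a modest move towards a higher number in this assay is expected, possibly not beyond the scatter. The expected step is a 1.6-fold higher number from compound 2 to compound 3 (0.21 log units; within the scatter). For compound 3 the estimated value is 3500 nM, with an expected range of 1500 nM to 7500 nM.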

Compound 3, half-maximal inhibitory concentration: 2420 nM
Compound 3: middle estimate off by 1.4-fold (0.16 log units), on the high side, and the stated range covers the measured number.
By their numbers in this assay, from the lowest: compounds 2 and 3 (each within the scatter of the next); then compound 1.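

In this assay, methoxy in place of bromo on this aromatic carbon gives a 1.1-fold higher number from compound 2 to compound 3 (0.05 log units; within the scatter), so the data do not separate the two groups, although methoxy brings a hydrogen-bond acceptor and bromo does not. Methoxy in place of hydrogen at the same carbon gives a 2.5-fold lower number from compound 1 to compound 3 (0.39 log units; beyond the scatter), which is beyond the scatter and in the same direction as a 2.7-fold lower number from compound 1 to compound 2 (0.44 log units; beyond the scatter), so for these two groups the lower number does not depend on bromo itself. No measurement in hand accounts for this result.

The three compounds leave open whether the lower number holds for other kinds of group on this carbon, such as an amine, a carboxylic acid or a longer chain such as butoxy, and so how far the trend reaches beyond bromo and methoxy. As far as these compounds go, all three also keep the rest of the shared core unchanged, so it remains open whether a change elsewhere on the core would add to the step seen at this carbon or cancel it.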